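Dropping the Methyl Group from Compound 3

The source may report more compounds than this note shows. Statements on the series, on what has been measured and on what is new or still open speak of the compounds shown alone.

Three compounds share one core. Compound 1 `Oc1ccc2cc3c(cc2n1)C1CNCC3C1` gives 8.5 nM in an assay for binding affinity to Neuronal acetylcholine receptor; alpha4/beta2 (Rattus norvegicus); on this read-out higher numbers stand for weaker inhibition and lower numbers for stronger inhibition. Compound 2 `Clc1ccc2cc3c(cc2n1)C1CNCC3C1` gives 0.27 nM in this assay; a 31-fold lower number from compound 1 to compound 2 (1.50 log units; beyond the scatter). Compound 3 `Cc1ccnc2cc3c(cc12)C1CNCC3C1` gives 1.8 nM in this assay, the second highest of the three numbers, lying between compound 1 and compound 2. Compound 4 `c1cnc2cc3c(cc2c1)C1CNCC3C1` is not yet measured; it differs from compound 3 by hydrogen in place of methyl on an aromatic carbon, opposite the ring nitrogen. Within the data shown here, the only measured step swaps hydroxy for chloro at another place, so no measured step bears on removing a methyl. A modest step is therefore expected, a 1.4-fold higher number from compound 3 to compound 4 (0.14 log units; within the scatter), possibly no more than the scatter. Compound 4 is expected to give about 2.5 nM, within 0.8 nM to 8 nM.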

Compound 4, inhibition constant: 1.6 nM
Compound 4: the middle estimate sits 1.6-fold (0.19 log units) above what was measured; low and high end bracket the measured number.
By their numbers in this assay, from the lowest: compound 2; then compounds 4 and 3 (each within the scatter of the next); then compound 1.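

At the aromatic carbon opposite the ring nitrogen, replacing methyl with hydrogen leaves the number in this assay essentially unchanged, with a 1.1-fold lower number from compound 3 to compound 4 (0.05 log units; within the scatter). Compound 4 also gives the chloro and hydroxy compounds a hydrogen reference at their own shared place: a 5.9-fold higher number from compound 2 to compound 4 (0.77 log units; beyond the scatter), and a 5.3-fold lower number from compound 1 to compound 4 (0.73 log units; beyond the scatter), so chloro and hydroxy move the number in opposite directions. No available evidence explains these steps. Only methyl and hydrogen are shown opposite the ring nitrogen, so it remains open whether an amine or a longer chain there would also leave the number unchanged.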